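Dimethylphenyl Analogue on a Piperazinyl Pyrazolopyrimidine Core

A few compounds are considered here, and "the series" means these few. Any claim that something is new, unique, unknown or untested is made for them only; others in the source may bear on it.

Measured so far:
compound 1, `Clc1ccc(Nc2cc(N3CCNCC3)nc3ccnn23)c(Cl)c1`: > 100000 nM
compound 2, `Fc1ccc(Nc2cc(N3CCNCC3)nc3ccnn23)c(F)c1`: > 100000 nM

In an assay on isolated protein for inhibition of Dipeptidyl peptidase 9 (Homo sapiens) (on this read-out lower numbers stand for stronger inhibition and higher numbers for weaker inhibition), compound 1 reaches only the limit of the assay, > 100000 nM. Compound 2 likewise reaches only a limit, > 100000 nM. The step that the two limits leave unreadable from compound 1 to compound 2 therefore cannot be read, since both values sit at the limit of > 100000 nM in this assay, at which 2 of the 2 values shown sit. Compound 3, `Cc1ccc(Nc2cc(N3CCNCC3)nc3ccnn23)c(C)c1`, differs from compound 2 by 2,4-dimethylphenyl in place of 2,4-difluorophenyl on a nitrogen on an aromatic ring. For the measured compounds named here, no measured step bears on this change, and both neighbours stand at the limit, so no shift in this assay beyond the scatter is expected; compound 3 is expected near 150000 nM, between 30000 nM and 1000000 nM. The expected step is a step that the limit leaves unreadable from compound 2 to compound 3.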

Compound 3, half-maximal inhibitory concentration: > 100000 nM
Compound 3: no number, only a limit; the forecaster's own chance of this, stated with the estimate: 85%; the middle value lies beyond the limit too.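

The steps among compound 1, compound 2 and compound 3 cannot be read in this assay, since all three values are limits: the limit of > 100000 nM in this assay, at which 3 of the 3 values shown sit.

The compounds shown leave open whether any group in this place on the shared core gives inhibition that can be put to a number.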